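Phenoxy in place of 4-methoxyphenyl on a shared core

The source may hold more compounds than are shown below. What is called first, only, known or untested is meant among the compounds shown, and "the series" means these compounds.

Compound 1 (`COc1ccc(Cn2nnc(O)c2C(=O)Nc2cccc(C(F)(F)F)c2)cc1`) gives 81400 nM
Compound 2 (`COc1ccc(Cn2nnc(O)c2C(=O)Nc2cccc(-c3ccc(O)cc3)c2)cc1`) gives 67500 nM
Compound 3 (`COc1ccc(Cn2nnc(O)c2C(=O)Nc2cccc(-c3ccc(OC)cc3)c2)cc1`) gives 50100 nM

All three values come from a functional assay on CWR22R cells (Homo sapiens) for inhibition, read by sulforhodamine B assay, with a stated time of 72 h (a lower number here means a stronger inhibitor, a higher number a weaker inhibitor), and they sit close together. Compound 3 stands within the scatter of both others, with a 1.3-fold lower number from compound 2 to compound 3 (0.13 log units; within the scatter) and a 1.6-fold lower number from compound 1 to compound 3 (0.21 log units; within the scatter) on the numbers shown.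

Compound 4 (`COc1ccc(Cn2nnc(O)c2C(=O)Nc2cccc(Oc3ccccc3)c2)cc1`) differs from compound 3 in one place: phenoxy in place of 4-methoxyphenyl on an aromatic carbon (phenoxy in place of 4-methoxyphenyl on an aromatic carbon, meta to a large group). For the measured compounds named here, no measured step introduces phenoxy itself. Two measured steps also exchange a group on an aromatic carbon, a 1.2-fold lower number from compound 1 to compound 2 (0.08 log units; within the scatter) and a 1.6-fold lower number from compound 1 to compound 3 (0.21 log units; within the scatter) in this series. A third, methyl in place of hydrogen on an oxygen on an aromatic ring, is a 1.3-fold lower number from compound 2 to compound 3 (0.13 log units; within the scatter) as measured. All three stay within the scatter, so no step beyond the scatter is expected in this assay here.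

The expected step is a 1.1-fold higher number from compound 3 to compound 4 (0.04 log units; within the scatter) by this estimate. Compound 4 is estimated at 55000 nM, with an expected range from 28000 nM to 100000 nM in this assay.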

Compound 4, half-maximal inhibitory concentration: 65000 nM
Compound 4: the middle estimate sits 1.2-fold (0.07 log units) below what was measured; measured number inside the range.
By their numbers in this assay, from the lowest: compounds 3, 4, 2 and 1 (each within the scatter of the next).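

In this assay, phenoxy on this aromatic carbon, meta to a large group, gives a 1.3-fold higher number from compound 3 to compound 4 (0.11 log units; within the scatter) when it takes the place of 4-methoxyphenyl, and a 1.0-fold lower number from compound 2 to compound 4 (0.02 log units; within the scatter) when it takes the place of 4-hydroxyphenyl. In place of trifluoromethyl it gives a 1.3-fold lower number from compound 1 to compound 4 (0.10 log units; within the scatter), so a fourth group at this position also fails to separate from the others, and every step among the four compounds stays within the scatter. Nothing available here accounts for this flat result.

The compounds shown leave open whether a group such as an amine or a carboxylic acid at this position would move the number beyond the scatter. They also leave open whether a change elsewhere on the shared core would do so.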